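The source may report more compounds than this note shows. Statements on the series, on what has been measured and on what is new or still open speak of the compounds shown alone.

Measured so far in an ADME assay for permeability, using PAMPA, with a stated time of 30 min, at pH 7.4; on this read-out higher numbers stand for higher permeability and lower numbers for lower permeability:
compound 1, `COc1cccc(CNCCCNc2ccnc3cc(-c4ccc(F)cc4)ccc23)c1O`, 237 10^-6 cm/s
compound 2, `COc1cccc(CNCCCNc2ccnc3cc(Cc4cc(C)cc(C)c4)ccc23)c1O`, 23 10^-6 cm/s

Among the measured compounds shown here, compound 2 stands lowest of the two numbers in this assay; its nearest neighbour is compound 1, and the only measured step is a 10-fold lower number from compound 1 to compound 2 (1.01 log units; beyond the scatter), which carried the exchange of 4-fluorophenyl for 3,5-dimethylbenzyl on an aromatic carbon.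

Compound 3, `COc1cccc(Oc2ccc3c(NCCCNCc4cccc(OC)c4O)ccnc3c2)c1`, is not yet measured. It differs from compound 2 in one place: 3-methoxyphenoxy in place of 3,5-dimethylbenzyl on an aromatic carbon. The measured step of a 10-fold lower number from compound 1 to compound 2 (1.01 log units; beyond the scatter) bears on it only loosely: it shows that an exchange at this place on the shared core can move the number far beyond the scatter, but it does not set an aryloxy group against a benzyl group, so no direction follows from it with confidence. Compound 1, which carries 4-fluorophenyl on an aromatic carbon of the core, gives the higher of the two numbers, and on that slender ground compound 3 is expected to lie above compound 2, the step from compound 2 to compound 3 being estimated as a 3.0-fold higher number from compound 2 to compound 3 (0.48 log units; beyond the scatter). Compound 3 is therefore estimated at 70 10^-6 cm/s in this assay, with a range from 20 10^-6 cm/s to 240 10^-6 cm/s, and a number rather than a limit is expected.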

Compound 3, apparent permeability: 317 10^-6 cm/s
For compound 3 the middle estimate is 4.5-fold (0.66 log units) below the measured one, and the stated range ends below it.
By their numbers in this assay, from the lowest: compound 2; then compounds 1 and 3 (each within the scatter of the next).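

Read in this assay, the place on the shared core now shows a large rise as well as a large fall: a 14-fold higher number from compound 2 to compound 3 (1.14 log units; beyond the scatter) follows the exchange of 3,5-dimethylbenzyl for 3-methoxyphenoxy, at equal heavy-atom count and with one six-membered aromatic ring of carbon only on each side. The second comparison, a 1.3-fold higher number from compound 1 to compound 3 (0.13 log units; within the scatter), places 3-methoxyphenoxy and 4-fluorophenyl level with each other, so two different groups at this aromatic carbon give numbers that cannot be told apart, and among these three compounds only compound 2, with its 3,5-dimethylbenzyl group, stands apart. No measurement in hand bears on the reason for this separation.

Compound 2 differs from the other two in both the link to the core and the substituents on the outer ring, so the shown compounds cannot assign its lower number to either feature; an unsubstituted benzyl group and a 3,5-dimethylphenoxy group would pull the two apart. As far as these compounds go, whether a group without an outer aromatic ring, such as a morpholine or a carboxylic acid, holds the number at this place also remains open.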